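The source may report more compounds than this note shows. Statements on the series, on what has been measured and on what is new or still open speak of the compounds shown alone.

Working notes on the series.

Compound 1 `CC(=O)OC/C(=C\c1ccccc1F)C(=O)c1ccccc1` in a functional assay on A549 cells (Homo sapiens) for inhibition, read by XTT assay, with a stated time of 48 h (a lower number here means a stronger inhibitor, a higher number a weaker inhibitor), gives 68700 nM. Compound 2 `C=C(C/C(=C\c1ccc(OC(=O)c2ccccc2)cc1)C(=O)c1ccc(OC)cc1)C(=O)c1ccc(OC)cc1` in this assay gives only a limit, > 100000 nM, where (the limit of > 100000 nM in this assay, at which 1 of the 3 values shown sits). Compound 3 `C=C(C/C(=C\c1ccccc1)C(=O)c1ccc(OC)cc1)C(=O)c1ccc(OC)cc1` in this assay gives 22900 nM. Among the compounds with values here, the one step between measured neighbours, an at least 4.3-fold lower number from compound 2 to compound 3 (0.64 log units; beyond the scatter), is the only measured change at the ring position that matters here, and it starts from a limit.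

Compound 3 holds the lowest of the two numbers shown; compound 1 gives the higher number, and that gap is beyond the scatter, so compound 3 is the stronger of the two measured with a number.

Compound 4 `C=C(C/C(=C\c1ccc(C)cc1)C(=O)c1ccc(OC)cc1)C(=O)c1ccc(OC)cc1` differs from compound 3 by methyl in place of hydrogen on an aromatic carbon. The measured step bears on it only loosely: removing the benzoyloxy group from that aromatic carbon gave a lower number from compound 2 to compound 3, but the group entering here is a single carbon, not a large ester, so no comparable move is expected. For compound 4 the step of a 1.0-fold lower number from compound 3 to compound 4 (0.02 log units; within the scatter) is estimated to stay within the scatter. Compound 4 in this assay is therefore expected to give about 22000 nM, with a likely range from 8000 nM to 60000 nM.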

Compound 4, half-maximal inhibitory concentration: 43800 nM
The estimate for compound 4 lay 2.0-fold (0.30 log units) below the measured number; low and high end bracket the measured number.
By their numbers in this assay, from the lowest: compounds 3, 4 and 1 (each within the scatter of the next, the first and the last beyond it). At a limit, above all of these: compound 2.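

Methyl in place of hydrogen at this position, on an aromatic carbon para to a large group, is the first small change measured here, and it stays within the scatter (a 1.9-fold higher number from compound 3 to compound 4 (0.28 log units; within the scatter)), so phenyl to 4-methylphenyl gives no clear change in this assay. The second step (an at least 2.2-fold lower number from compound 2 to compound 4 (0.35 log units; beyond the scatter)) lies beyond the scatter and shows that the gain on losing benzoyloxy, first seen with hydrogen in compound 3, also appears with methyl in compound 4, so it does not depend on that one replacement. That gain has only a lower bound, since compound 2 stands at a limit and not at a number: the limit of > 100000 nM in this assay, at which 1 of the 4 values shown sits.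

The compounds shown leave open how an amine, a carboxylic acid or a longer chain at this same position would read in this assay, and where between methyl and benzoyloxy the number starts to be lost. Compound 1 differs from the others in more than one place, so its number says nothing about this position.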